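This account rests on a few compounds, and the source may have more. Where it says the series, first, only, none or still open, it means among the compounds named here.

In a functional assay on MDA cells (Homo sapiens) for inhibition, read by MTT assay, with a stated time of 48 h (a higher number here means a weaker inhibitor, a lower number a stronger inhibitor), compound 1 (`O=C(CCCCOc1no[n+]([O-])c1S(=O)(=O)c1ccccc1)NO`) gives 2530 nM and compound 2 (`O=C(CCCCCCCOc1no[n+]([O-])c1S(=O)(=O)c1ccccc1)NO`) gives 2700 nM and so stands level with compound 1. Within the data shown here, the one measured step (a 1.1-fold higher number from compound 1 to compound 2 (0.03 log units; within the scatter)) changes the chain length and stays within the scatter. Compound 3 (`O=C(NO)OCCOCCOc1no[n+]([O-])c1S(=O)(=O)c1ccccc1`) carries 2-((hydroxycarbamoyl)oxy)ethoxy in place of 5-(hydroxycarbamoyl)pentyl on a saturated chain carbon, two bonds along the chain from an oxygen on an aromatic ring. Among the measured compounds shown here, no measured compound tests such a chain, so no direction can be argued, and no shift beyond the scatter is expected. The expected step (a 1.1-fold higher number from compound 2 to compound 3 (0.05 log units; within the scatter)) is therefore small but uncertain. For compound 3 the estimated value is 3000 nM (expected range 1000 nM to 9000 nM).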

Compound 3, half-maximal inhibitory concentration: 15800 nM
Estimate against measurement, compound 3: 5.3-fold (0.72 log units) below; the whole stated range lies below it.
By their numbers in this assay, from the lowest: compounds 1 and 2 (each within the scatter of the next); then compound 3.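

At this position, on a saturated chain carbon, the make-up of the chain matters: 2-((hydroxycarbamoyl)oxy)ethoxy in place of 5-(hydroxycarbamoyl)pentyl weakens inhibition (a 5.9-fold higher number from compound 2 to compound 3 (0.77 log units; beyond the scatter)), and the same holds against 2-(hydroxycarbamoyl)ethyl (a 6.2-fold higher number from compound 1 to compound 3 (0.80 log units; beyond the scatter)), whereas the change of chain length alone stayed within the scatter. Compound 3 is thus the weakest of the three. Nothing measured here accounts for this loss. The change alters the chain and its link to the hydroxycarbamoyl group together, so the compounds shown cannot say which part carries the loss. As far as these compounds go, whether an ether chain ending in a plain hydroxycarbamoyl group, or in a carboxylic acid, would keep the activity stays open.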